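The source may hold more compounds than are shown below. What is called first, only, known or untested is meant among the compounds shown, and "the series" means these compounds.

The measured compounds in an assay on isolated protein for inhibition of NUAK family SNF1-like kinase 2 (Homo sapiens), read by ADP-Glo, with a stated time of 60 min, tested at 10 uM, in the presence of a further agent that is not named here; on this read-out higher numbers stand for more inhibition at the one concentration tested (going by the name of the read-out) and lower numbers for less inhibition:
compound 1 `CCC(=O)Nc1cccc(Oc2nc(Nc3ccc(N(C)C)cc3OC)ncc2Cl)c1` gives 15%;
compound 2 `CCC(=O)Nc1cccc(Oc2nc(Nc3ccc(N4CCN(C)CC4)cc3Cl)ncc2Cl)c1` gives 69.1%;
compound 3 `CCC(=O)Nc1cccc(Oc2nc(Nc3ccc(N(C)C)cc3)ncc2Cl)c1` gives 31.7%.

Compound 3 stands second highest of these three numbers; its nearest neighbour is compound 1, which lies below it beyond the scatter, and the furthest is compound 2, which lies above it beyond the scatter. For the measured compounds named here, the only step measured in a single place, a number 16.7 percentage points higher from compound 1 to compound 3 (beyond the scatter), concerns hydrogen in place of methoxy on an aromatic carbon and leaves the amine untouched.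

Compound 4 `CCC(=O)Nc1cccc(Oc2nc(Nc3ccc(N4CCC(OC)CC4)cc3)ncc2Cl)c1` differs from compound 3 in one place: 4-methoxypiperidin-1-yl in place of dimethylamino on an aromatic carbon. Going by the values given here, no measured step bears directly on this exchange. Compound 2 carries a six-membered ring amine on the same part of the shared core and gives the highest number of the three, but it also differs from compound 3 in a second place, so its value cannot be credited to the ring amine alone. The expectation for compound 4 is therefore a modest rise, a number 10.3 percentage points higher from compound 3 to compound 4 (beyond the scatter), with wide uncertainty. Compound 4 is estimated at 42%, between 15% and 70%.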

Compound 4, a percentage reported as inhibition, at one concentration (the size of the read-out at that concentration, not a potency): 53.4%
Beside the measured number, compound 4's estimate is 11.4 percentage points below it; measured number inside the range.
By their numbers in this assay, from the lowest: compound 1; then compound 3; then compound 4; then compound 2.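

In this assay, for the compounds shown here, the exchange of dimethylamino for 4-methoxypiperidin-1-yl gives a number 21.7 percentage points higher from compound 3 to compound 4 (beyond the scatter), and this is the first measured change at this position, on an aromatic carbon para to a large group, made with nothing else in the molecule altered. It shows that the number at this position responds to the amine group alone, and that a group of 8 heavy atoms with one six-membered non-aromatic ring, entering where 3 heavy atoms with no ring leave, goes with more inhibition at the one concentration tested, not less. Nothing measured here accounts for this rise, and the step records only that it occurs.

The exchange brings in the ring and the methoxy together, so the compounds shown leave open how much of the step belongs to each, and a plain piperidin-1-yl or a morpholine ring in the same place would speak to that. Also open, as far as these compounds go, is whether the step would keep its size with methoxy or chlorine in place of the hydrogen elsewhere on that aromatic ring, and how it would read as a potency rather than as inhibition at a single concentration.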